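Fluoro removal on the benzyl group, repeated on another core

This account rests on a few compounds, and the source may have more. Where it says the series, first, only, none or still open, it means among the compounds named here.

The measured compounds in a functional assay on CCRF-CEM cells (Homo sapiens) for cytotoxicity, read by cell counting, with a stated time of 3 days; on this read-out higher numbers stand for weaker inhibition and lower numbers for stronger inhibition:
compound 1, `C=C(Br)C(=O)Nc1ccc(/C=C2\SC(=O)N(Cc3ccccc3)C2=O)cc1`, gives 2300 nM;
compound 2, `C=C(Br)C(=O)Nc1ccc(/C=C2\SC(=O)N(Cc3ccc(F)cc3)C2=O)cc1`, gives 2400 nM;
compound 3, `C=C(Br)C(=O)Nc1cccc(/C=C2\SC(=O)N(Cc3ccc(F)cc3)C2=O)c1`, gives 680 nM.

Compound 2 and compound 1 differ by one change, (hydrogen in place of fluoro on an aromatic carbon), and this step gave a 1.0-fold lower number from compound 2 to compound 1 (0.02 log units; within the scatter). Compound 3 shares its atoms with compound 2 but they are joined differently; how the two cores differ is not broken down here. Compound 3 shows the lowest number of the three, with both compound 1 and compound 2 lying beyond the scatter above it.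

Compound 4, `C=C(Br)C(=O)Nc1cccc(/C=C2\SC(=O)N(Cc3ccccc3)C2=O)c1`, is compound 3 with the same change, (hydrogen in place of fluoro on an aromatic carbon), the place being the same word for word. Because the earlier step was a 1.0-fold lower number from compound 2 to compound 1 (0.02 log units; within the scatter), compound 4 is expected to give about 700 nM in this assay, between 350 nM and 1400 nM, the step of a 1.0-fold higher number from compound 3 to compound 4 (0.01 log units; within the scatter) being an estimate.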

Compound 4, half-maximal inhibitory concentration: 510 nM
Beside the measured number, compound 4's estimate is 1.4-fold (0.14 log units) above it; measured number inside the range.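

In this assay, replacing the fluoro of the 4-fluorobenzyl group with hydrogen gave a 1.3-fold lower number from compound 3 to compound 4 (0.12 log units; within the scatter). Set beside the same change on the core of compound 1, the two steps agree: the same change on two cores in this assay, a 1.0-fold lower number (0.02 log units; within the scatter) from compound 2 to compound 1 and a 1.3-fold lower number (0.12 log units; within the scatter) from compound 3 to compound 4, 1.3-fold (0.11 log units) apart, within the scatter of two such steps. This shows that on these two cores the 4-fluorobenzyl and benzyl groups could be exchanged with no change beyond the scatter, but it covers only a change with no readable effect on two cores, so it does not show that the same would hold on any other core, or that a change with a larger effect would carry over.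

The compounds shown leave open whether a chloro group, a methoxy group or an amine in the place of the fluoro would also leave the number unchanged. They also leave open how such a group would behave on each of the two cores.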